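Adding a methyl to the amide of compound 2

The source may hold more compounds than are shown below. What is called first, only, known or untested is meant among the compounds shown, and "the series" means these compounds.

Compound 1 `CCNC(=O)c1noc(-c2cc(C(C)C)c(O)cc2O)c1-c1cc(COCC(N)=O)no1` measures 97 nM
Compound 2 `CCNC(=O)c1noc(-c2cc(C(C)C)c(O)cc2O)c1-c1cc(C(N)=O)no1` measures 79 nM

For the measured compounds named here, in a functional assay on HCT-116 cells (Homo sapiens) for inhibition (on this read-out higher numbers stand for weaker inhibition and lower numbers for stronger inhibition), compound 2 stands level with compound 1, the only other compound measured so far. The numbers of these two cannot be told apart.

Compound 3 `CCNC(=O)c1noc(-c2cc(C(C)C)c(O)cc2O)c1-c1cc(C(=O)NC)no1` changes one thing in compound 2: methyl in place of hydrogen on an amide-type nitrogen, which turns carbamoyl into methylcarbamoyl (methyl in place of hydrogen on an amide-type nitrogen). Going by the values given here, the one measured step (a 1.2-fold lower number from compound 1 to compound 2 (0.09 log units; within the scatter)) put carbamoyl in place of (carbamoylmethoxy)methyl on an aromatic carbon and stayed small, so a large shift in this assay is not expected here. Among the compounds with values here, that evidence is indirect, as no measured pair tests the methyl itself. No step beyond the scatter is expected in either direction, and the estimate is correspondingly small (a 1.1-fold higher number from compound 2 to compound 3 (0.03 log units; within the scatter)). For compound 3 the expected value is 85 nM with an estimated range of 35 nM to 200 nM around it.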

Compound 3, half-maximal inhibitory concentration: 124 nM
Compound 3: the middle estimate sits 1.5-fold (0.16 log units) below what was measured; measured number inside the range.
By their numbers in this assay, from the lowest: compounds 2, 1 and 3 (each within the scatter of the next).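

In this assay, the amide hydrogen of the carbamoyl group can be replaced by methyl without a step that stands out from the scatter of repeated measurements (a 1.6-fold higher number from compound 2 to compound 3 (0.20 log units; within the scatter)). For the compounds shown here, this is the first pair to test the amide-type nitrogen directly, and the comparison with the longer group of compound 1 reads the same way (a 1.3-fold higher number from compound 1 to compound 3 (0.11 log units; within the scatter)), so carbamoyl, methylcarbamoyl and (carbamoylmethoxy)methyl at this place cannot be told apart on this read-out. Nothing beyond these cell numbers is available to bear on the result or to explain it.

The compounds shown leave open how much more this amide-type nitrogen can carry, for instance whether an ethyl or a longer chain, or a second methyl that would replace the remaining amide hydrogen, would still give a number in this range. They also leave open whether the amide can be exchanged altogether, since a carboxylic acid or an amine at the same place would show whether the carbonyl and nitrogen of the group matter to the read-out at all.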